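Shortening the amide chain: from compound 1 to compound 4

The source may hold more compounds than are shown below. What is called first, only, known or untested is meant among the compounds shown, and "the series" means these compounds.

Three compounds have so far been measured in a functional assay on B16-F10 cells (Mus musculus) for inhibition, read by MTT assay, with a stated time of 48 h; a lower number here means a stronger inhibitor, a higher number a weaker inhibitor:

compound 1 `CCCCCCCCNC(=O)/C=C/c1c(/C=C/c2ccc(OC)cc2)cc(OC)cc1OC`, 8060 nM
compound 2 `COc1ccc(/C=C/c2cc(OC)cc(OC)c2/C=C/C(=O)N2CCC(c3ccccc3)CC2)cc1`, 9180 nM
compound 3 `CCCCCN(CCCCC)C(=O)/C=C/c1c(/C=C/c2ccc(OC)cc2)cc(OC)cc1OC`, 9270 nM

Compound 1 gives the lowest of the three numbers, but the gaps to the others, a 1.1-fold higher number from compound 1 to compound 2 (0.06 log units; within the scatter) and a 1.2-fold higher number from compound 1 to compound 3 (0.06 log units; within the scatter), are both within the scatter, so no order among the three can be read from them. Compound 4 `CCCCCCNC(=O)/C=C/c1c(/C=C/c2ccc(OC)cc2)cc(OC)cc1OC` differs from compound 1 in one place: hydrogen in place of ethyl on a saturated chain carbon, six bonds along the chain from an amide-type nitrogen.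

All three measured steps change the group on the carbonyl carbon of the amide, and each is within the scatter: a 1.1-fold higher number from compound 1 to compound 2 (0.06 log units; within the scatter), a 1.2-fold higher number from compound 1 to compound 3 (0.06 log units; within the scatter) and a 1.0-fold higher number from compound 2 to compound 3 (0.00 log units; within the scatter). Replacing octylamino with a branched dipentylamino chain or a ring-bearing 4-phenylpiperidin-1-yl left the number essentially unchanged, which suggests that a smaller change, the loss of two chain carbons, is unlikely to move the number beyond the scatter either. The expected step for compound 4 is therefore a 1.1-fold higher number from compound 1 to compound 4 (0.02 log units; within the scatter) in this assay. Compound 4 is estimated at 8500 nM, within a range of 4000 nM to 18000 nM.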

Compound 4, half-maximal inhibitory concentration: 7180 nM
Estimate against measurement, compound 4: 1.2-fold (0.07 log units) above, and the stated range covers the measured number.
By their numbers in this assay, from the lowest: compounds 4, 1, 2 and 3 (each within the scatter of the next).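

In this assay, among the compounds shown here, the loss of ethyl at this place on the saturated chain, six bonds along the chain from the amide-type nitrogen, gives a 1.1-fold lower number from compound 1 to compound 4 (0.05 log units; within the scatter) and is the first change confined to the end of the chain rather than a swap of the whole group on the carbonyl carbon. Hexylamino also cannot be told apart from the two other groups, with a 1.3-fold lower number from compound 3 to compound 4 (0.11 log units; within the scatter) and a 1.3-fold lower number from compound 2 to compound 4 (0.11 log units; within the scatter), so all four amides stay without any order among them. Nothing measured in what is shown offers a reason for this flat response. The compounds shown leave open whether a much shorter chain such as propyl, or a chain ending in an amine or a carboxylic acid, would move the number beyond the scatter. They also leave open whether replacing the amide group itself on the shared core, for instance with a carboxylic acid, would do so.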